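This account rests on a few compounds, and the source may have more. Where it says the series, first, only, none or still open, it means among the compounds named here.

Series notes. Compound 3 `COc1ccc(/C=C/C(=O)Nc2cc(C(=O)c3cc(OC)c(OC)c(OC)c3)cc(OC)c2OC)cc1` reads in a functional assay on HT-29 cells (Homo sapiens) for cytotoxicity, read by MTT assay, with a stated time of 72 h (on this read-out higher numbers stand for weaker inhibition and lower numbers for stronger inhibition), at 3800 nM, the highest of the three numbers on hand, though neither gap reaches beyond the scatter. Nearest to it sits compound 2 `COc1ccc(/C=C/C(=O)Nc2cc(C(=O)c3cc(OC)c(OC)c(OC)c3)cc(OC)c2OC)cc1OC`, which in this assay gives 2300 nM. Furthest sits compound 1 `COc1cccc(/C=C/C(=O)Nc2cc(C(=O)c3cc(OC)c(OC)c(OC)c3)ccc2OC)c1`, which in this assay gives 1900 nM. Compound 4 `COc1cccc(/C=C/C(=O)Nc2cc(C(=O)c3cc(OC)c(OC)c(OC)c3)cc(OC)c2OC)c1` has not yet been measured. It differs from compound 3 in one place: 3-methoxyphenyl in place of 4-methoxyphenyl on a double-bonded chain carbon bound to a double-bonded chain carbon. Within the data shown here, the only measured single step that touches this ring is a 1.7-fold higher number from compound 2 to compound 3 (0.22 log units; within the scatter), a change that stays within the scatter. Among the measured compounds shown here, compound 1 carries the same 3-methoxyphenyl that enters in compound 4, but on a core that differs from that of compound 3 in a second place, so no single step can be drawn between them; what the two values show is that compound 1 and compound 3 lie within the scatter of each other. On this basis no step beyond the scatter is expected in this assay for the change from compound 3 to compound 4. The expected step is a 1.5-fold lower number from compound 3 to compound 4 (0.16 log units; within the scatter). Compound 4 is estimated in this assay at 2600 nM, with a range from 1000 nM to 6500 nM.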

Compound 4, half-maximal inhibitory concentration: 8700 nM
Beside the measured number, compound 4's estimate is 3.3-fold (0.52 log units) below it; the whole stated range lies below it.
By their numbers in this assay, from the lowest: compounds 1, 2 and 3 (each within the scatter of the next); then compound 4.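

In this assay, among these compounds, the place of the single methoxy on this ring now counts: 3-methoxyphenyl in place of 4-methoxyphenyl gives a 2.3-fold higher number from compound 3 to compound 4 (0.36 log units; beyond the scatter), the first step beyond the scatter. Compound 4 also stands apart from both of its other single-change neighbours, with hydrogen in place of methoxy on the ring on the double-bonded chain carbon giving a 3.8-fold higher number from compound 2 to compound 4 (0.58 log units; beyond the scatter), and methoxy in place of hydrogen on the other side of the amide giving a 4.6-fold higher number from compound 1 to compound 4 (0.66 log units; beyond the scatter); 3-methoxyphenyl therefore does not set the number alone, as compound 1 carries the same group and gives the lowest number on hand, though within the scatter of compound 2 and compound 3. Hydrogen in place of methoxy does not read alike across the two settings: the same change on two cores in this assay, a 1.7-fold higher number (0.22 log units; within the scatter) from compound 2 to compound 3 and a 4.6-fold lower number (0.66 log units; beyond the scatter) from compound 4 to compound 1, 7.6-fold (0.88 log units) apart, beyond the scatter of two such steps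

Whether 3-methoxyphenyl in place of 4-methoxyphenyl gives a similar step on the core of compound 1 stays open, as no compound shown pairs that core with 4-methoxyphenyl. Also open, going by these compounds, is what a hydroxy group or an amine in place of the methoxy of 3-methoxyphenyl would give.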